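The source may report more compounds than this note shows. Statements on the series, on what has been measured and on what is new or still open speak of the compounds shown alone.

Working notes on the series in an ADME assay on HepG2 cells (Homo sapiens) for cytotoxicity, read by luminescence, CellTiter-Glo and ATP content, with a stated time of 72 h; a lower number here means that less compound is needed, a higher number that more compound is needed for the effect. For the measured compounds named here, compound 2 `COc1ccc(F)cc1CNCCCNc1ccnc2cc(CCc3ccccc3)ccc12` gives 4240 nM, the lowest of the three numbers measured so far. Compound 1 `Fc1ccc(Cc2ccc3c(NCCCNCc4ccco4)ccnc3c2)c(Cl)c1` gives 5730 nM, which lies within the scatter of compound 2. Compound 3 `c1ccc(CCc2ccc3c(NCCCNCc4ccco4)ccnc3c2)cc1` gives 16000 nM, the furthest from compound 2; the step of a 3.8-fold higher number from compound 2 to compound 3 (0.58 log units; beyond the scatter) is beyond the scatter, as is the other measured step, a 2.8-fold higher number from compound 1 to compound 3 (0.45 log units; beyond the scatter).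

Compound 4 `COc1ccc(F)cc1CNCCCNc1ccnc2cc(Oc3ccc(F)cc3)ccc12` is not yet measured. It differs from compound 2 in one place: 4-fluorophenoxy in place of phenethyl on an aromatic carbon. Neither measured step bears on this place. The step from compound 1 to compound 3 changes the group on a saturated chain carbon bound to an aromatic carbon, and the step from compound 2 to compound 3 changes the group on a saturated chain carbon bound to an amine nitrogen; the aromatic carbon of the fused core is left untouched in both. Going by the values given here, no measured step therefore speaks to the change in compound 4, and the expectation for compound 4 is a step of a 1.2-fold higher number from compound 2 to compound 4 (0.07 log units; within the scatter) in this assay, nothing beyond the scatter. The estimated value for compound 4 in this assay is 5000 nM, with a range from 2000 nM to 12500 nM.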

Compound 4, half-maximal effective concentration: 6600 nM
The estimate for compound 4 lay 1.3-fold (0.12 log units) below the measured number, within the range that was stated.
By their numbers in this assay, from the lowest: compounds 2, 1 and 4 (each within the scatter of the next); then compound 3.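

For the compounds shown here, at this aromatic carbon of the shared core, meta to a fused ring and para to a fused ring, the exchange of phenethyl for 4-fluorophenoxy gives the first reading of this place in this assay: a 1.6-fold higher number from compound 2 to compound 4 (0.19 log units; within the scatter). The two groups match in their count of 8 heavy atoms and in their one six-membered aromatic ring of carbon only, while 4-fluorophenoxy brings an oxygen, a fluorine and 1 hydrogen-bond acceptor, and with these differences the two numbers still cannot be told apart. Nothing on hand offers an explanation for this result.

With the 5-fluoro-2-methoxyphenyl group on the amine side, the compounds shown carry only phenethyl and 4-fluorophenoxy at this carbon, so it stays open whether an amine, a carboxylic acid or a longer chain there would give a step beyond the scatter. It also stays open whether 4-fluorophenoxy gives a similar reading with furan-2-yl on the amine side, where the compounds shown carry only phenethyl and the benzyl group bearing 2-chloro-4-fluorophenyl at this carbon.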